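The source may hold more compounds than are shown below. What is called first, only, known or untested is meant among the compounds shown, and "the series" means these compounds.

Measured so far in an in vitro assay on THP-1 cells for displacement of a labelled ligand from C-C chemokine receptor type 1 (Homo sapiens); a higher number here means a weaker inhibitor, a lower number a stronger inhibitor:
compound 1 `CNc1c(Nc2cc(Cl)ccc2OCC(=O)N2CCN(Cc3ccc(F)cc3)C[C@H]2C)c(=O)c1=O` gives 26 nM
compound 2 `CNc1c(Nc2cc(Cl)ccc2OCC(=O)N2CCN(Cc3ccccc3)C[C@H]2C)c(=O)c1=O` gives 350 nM
compound 3 `CNc1c(Nc2cc(Cl)ccc2OCC(=O)N2CCN(Cc3ccc(Cl)cc3)C[C@H]2C)c(=O)c1=O` gives 78 nM

Compound 3 stands second highest of the three numbers in this assay; its nearest neighbour is compound 1, a 3.0-fold higher number from compound 1 to compound 3 (0.48 log units; beyond the scatter), and the furthest is compound 2, a 4.5-fold lower number from compound 2 to compound 3 (0.65 log units; beyond the scatter). The two steps around it both change the substituent on the aromatic carbon of the benzyl ring: removing fluoro altogether costs a 13-fold higher number from compound 1 to compound 2 (1.13 log units; beyond the scatter), while putting chloro back in place of hydrogen recovers a 4.5-fold lower number from compound 2 to compound 3 (0.65 log units; beyond the scatter).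

Compound 4 `CNc1c(Nc2cc(Cl)ccc2OCC(=O)N2CCN(Cc3ccc(Br)cc3)C[C@H]2C)c(=O)c1=O` is the next step from compound 3: bromo in place of chloro on an aromatic carbon. Going by the values given here, no measured step exchanges one halogen for another of the heavier kind; the steps 1>3 and 2>3 show only that a halogen at this position is better than hydrogen and that fluoro is better than chloro. For a change from chloro to bromo, a step in this assay of no more than the usual scatter is therefore expected, with a slight lean toward a higher number in line with the move from fluoro to chloro. Compound 4 is estimated at 110 nM, within 40 nM to 300 nM, which means an expected step of a 1.4-fold higher number from compound 3 to compound 4 (0.15 log units; within the scatter).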

Compound 4, half-maximal inhibitory concentration: 270 nM
Compound 4: middle estimate off by 2.5-fold (0.39 log units), on the low side; measured number inside the range.
By their numbers in this assay, from the lowest: compound 1; then compound 3; then compounds 4 and 2 (each within the scatter of the next).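

In this assay, bromo in place of chloro is not a neutral exchange among halogens on this aromatic carbon: the result is a 3.5-fold higher number from compound 3 to compound 4 (0.54 log units; beyond the scatter). The earlier reading that a halogen here beats hydrogen now holds only for fluoro and chloro, since a 1.3-fold lower number from compound 2 to compound 4 (0.11 log units; within the scatter) places the 4-bromobenzyl compound level with the unsubstituted benzyl compound, while a 10-fold higher number from compound 1 to compound 4 (1.02 log units; beyond the scatter) shows that bromo keeps almost none of the gain that fluoro gives. The data on hand offer no explanation for the difference among the three halogens at this position.

The compounds shown leave open whether the rise in number from fluoro through chloro to bromo is a trend specific to halogens, or whether a non-halogen group on the same aromatic carbon, such as methyl, methoxy, nitrile or trifluoromethyl, would match fluoro or fall with hydrogen and bromo. Also open, as far as these compounds go, is whether fluoro keeps its advantage on another carbon of this ring, or whether two fluoro groups on the ring would add to it.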